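The source may report more compounds than this note shows. Statements on the series, on what has been measured and on what is new or still open speak of the compounds shown alone.

Measured compounds:
Compound 1, `N[C@H]1CC[C@H](CN(C[C@H]2Cc3ccccc3CN2)[C@H]2CCCc3cccnc32)CC1`: 280 nM
Compound 2, `C/C(CN)=C(\F)CN(C[C@H]1Cc2ccccc2CN1)[C@H]1CCCc2cccnc21`: 28 nM
Compound 3, `C/C(CN(C[C@H]1Cc2ccccc2CN1)[C@H]1CCCc2cccnc21)=C(\F)CN`: 80 nM

In a functional assay on CCRF-CEM cells for antagonist activity at C-X-C chemokine receptor type 4 (Homo sapiens), read by calcium flux, with stated times of 25 min and 90 s (on this read-out lower numbers stand for stronger inhibition and higher numbers for weaker inhibition), compound 3 stands second highest of the three numbers. Its nearest neighbour is compound 2, a step of a 2.9-fold higher number from compound 2 to compound 3 (0.46 log units; beyond the scatter); its furthest is compound 1, a step of a 3.5-fold lower number from compound 1 to compound 3 (0.54 log units; beyond the scatter).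

Compound 4, `N[C@H]1CC[C@H](N(C[C@H]2Cc3ccccc3CN2)[C@H]2CCCc3cccnc32)CC1`, is still to be measured. It differs from compound 3 by 4-aminocyclohexyl in place of 4-amino-3-fluoro-2-methylbut-2-en-1-yl on an amine nitrogen. The 4-aminocyclohexyl group is thus placed directly on the amine nitrogen, whereas in compound 1 the same group sits on a saturated chain carbon bound to that nitrogen.

The step that bears on this change is a 3.5-fold lower number from compound 1 to compound 3 (0.54 log units; beyond the scatter), which ran in the opposite sense. Reversing the replacement would point to a higher number for compound 4, of about that size, though the missing chain carbon leaves the outcome less certain. Compound 4 is therefore expected to give 300 nM, within 80 nM to 1200 nM, an estimated step of a 3.8-fold higher number from compound 3 to compound 4 (0.57 log units; beyond the scatter).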

Compound 4, half-maximal inhibitory concentration: 34 nM
For compound 4 the middle estimate is 8.8-fold (0.95 log units) above the measured one; measured number outside the range, below it.
By their numbers in this assay, from the lowest: compounds 2 and 4 (each within the scatter of the next); then compound 3; then compound 1.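

In this assay, moving 4-aminocyclohexyl onto the amine nitrogen, with no chain carbon in between, gives an 8.2-fold lower number from compound 1 to compound 4 (0.92 log units; beyond the scatter), so the high number of compound 1 does not follow from the 4-aminocyclohexyl group alone. At this place a saturated ring can also replace the open-chain groups: the change shows a 1.2-fold higher number from compound 2 to compound 4 (0.08 log units; within the scatter) for 3-(aminomethyl)-2-fluorobut-2-en-1-yl and a 2.4-fold lower number from compound 3 to compound 4 (0.37 log units; beyond the scatter) for 4-amino-3-fluoro-2-methylbut-2-en-1-yl. No measurement given here explains these differences.

The compounds shown leave open whether the primary amine on the cyclohexyl ring is needed, since a hydroxyl group or a piperidine ring with its nitrogen inside the ring could take the same place on the amine nitrogen. They also leave open how the other stereoisomer of 4-aminocyclohexyl would compare.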